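Trifluoromethyl ketone replaces benzamide on a shared core

The source may hold more compounds than are shown below. What is called first, only, known or untested is meant among the compounds shown, and "the series" means these compounds.

Measured compounds:
- compound 1, `Nc1ccccc1NC(=O)CCCCCCc1nc(-c2ccc(C(F)(F)F)cc2)no1`: > 10000 nM
- compound 2, `Nc1ccccc1NC(=O)CCCCCCc1nc(-c2ccccc2Cl)no1`: > 10000 nM
- compound 3, `Nc1ccccc1NC(=O)CCCCCCc1nc(-c2ccc([N+](=O)[O-])cc2)no1`: > 10000 nM

In an assay on isolated protein for inhibition of histone deacetylase 8 (Homo sapiens), read by fluorescence, with a stated time of 10 min (on this read-out higher numbers stand for weaker inhibition and lower numbers for stronger inhibition), compound 3 reaches only the limit of the assay, > 10000 nM, and not a number. Compound 1 likewise gives only a limit in this assay. Compound 2 also gives only a limit. So (the limit of > 10000 nM in this assay, at which 3 of the 3 values shown sit), and the steps between them, a step that the two limits leave unreadable from compound 1 to compound 2, a step that the two limits leave unreadable from compound 1 to compound 3 and a step that the two limits leave unreadable from compound 2 to compound 3, cannot be read in size or direction.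

The unmeasured compound 4, `O=C(CCCCCCc1nc(-c2ccc([N+](=O)[O-])cc2)no1)C(F)(F)F`, differs from compound 3 in one place: trifluoromethyl in place of (2-aminophenyl)amino on a carbonyl carbon. Among the compounds with values here, none of the measured steps touches this part of the molecule; they all vary the aryl group on the other end of the shared core, and all three sit at the limit. The measured steps therefore give no guide to the size or direction of the new step, and the expectation rests on the change itself.

Compound 4 is estimated at 1500 nM, within 150 nM to 10000 nM, which as a step is expected to be an at least 6.6-fold lower number from compound 3 to compound 4 (0.82 log units; beyond the scatter).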

Compound 4, half-maximal inhibitory concentration: 3170 nM
For compound 4 the middle estimate is 2.1-fold (0.32 log units) below the measured one, within the range that was stated.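

Within the data shown here, compound 4 is the only compound here that gives a number rather than a limit in this assay, so the carbonyl end of the shared core is the first place where a change can be read. Putting trifluoromethyl in place of (2-aminophenyl)amino on the carbonyl carbon gives an at least 3.1-fold lower number from compound 3 to compound 4 (0.49 log units; beyond the scatter), which shows that inhibition can be measured on this core without the (2-aminophenyl)amino group and its aromatic ring. On these data alone, the true size of the step stays open on one side, as compound 3 has only a limit and not a number.

As far as these compounds go, the three aryl groups cannot be compared with one another, and their steps cannot be read in size or direction, so it remains open whether the aryl group matters once trifluoromethyl sits on the carbonyl carbon: the limit of > 10000 nM in this assay, at which 3 of the 4 values shown sit. Also open are how other groups on this carbonyl carbon, such as a hydroxyamino group or a methyl group, or a longer chain would compare, and whether the step comes from losing (2-aminophenyl)amino or from gaining trifluoromethyl.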